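Chloro for methyl on the aryl ring of compound 3

The source may hold more compounds than are shown below. What is called first, only, known or untested is meant among the compounds shown, and "the series" means these compounds.

Measured compounds in an assay on isolated protein for inhibition of Polyunsaturated fatty acid 5-lipoxygenase (Homo sapiens); on this read-out lower numbers stand for stronger inhibition and higher numbers for weaker inhibition:
- compound 1 `O=C1CCCN(c2ccc(Cl)cc2)N1`: 79000 nM
- compound 2 `COc1ccccc1N1CCCC(=O)N1`: 204000 nM
- compound 3 `Cc1cccc(N2CCC(=O)N2)c1`: 1300 nM

Compound 3 stands lowest of the three numbers in this assay, and both gaps are beyond the scatter: compound 1 is the nearest, compound 2 the furthest. On these three numbers compound 3 is therefore the strongest inhibitor of the set; note that it also differs from compounds 1 and 2 in its core, so the three do not form a single-change series and nothing is known about any one change among them.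

The next compound, compound 4 `O=C1CCN(c2cccc(Cl)c2)N1`, keeps the core of compound 3 and differs from it in one place: chloro in place of methyl on an aromatic carbon. Among the measured compounds shown here, no single-change step among the measured compounds is available to size this change, so the expectation rests on the general run of the three values only. A small step is expected in this assay, in either direction and possibly not beyond the scatter. Compound 4 is expected to give about 1500 nM, within 400 nM to 6000 nM. The estimated step is a 1.2-fold higher number from compound 3 to compound 4 (0.06 log units; within the scatter).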

Compound 4, half-maximal inhibitory concentration: 730 nM
Compound 4: middle estimate off by 2.1-fold (0.31 log units), on the high side; the range from low to high includes it.
By their numbers in this assay, from the lowest: compounds 4 and 3 (each within the scatter of the next); then compound 1; then compound 2.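

Among the compounds shown here, compound 4 gives the first single-change step: in this assay, chloro in place of methyl on an aromatic carbon, meta to a group of 6 heavy atoms, gives a 1.8-fold lower number from compound 3 to compound 4 (0.25 log units; within the scatter) and so does not separate the two groups at this position. The earlier compounds shown here could not show this, since compounds 1 and 2 differ from compound 3 in more than one place and offer no read on any single position. Nothing available here bears on why this exchange of one heavy atom for another leaves the value within the scatter.

For the compounds shown here, the step covers only two groups, each of a single heavy atom and without hydrogen-bond donors or acceptors, so it remains open whether a larger or quite different group at this carbon, such as an amine, a carboxylic acid or a longer chain, would move the number beyond the scatter. Also open, on these data alone, is how the ring carbon would read with hydrogen alone in place of methyl or chloro, which would show whether either group contributes at all to the values of the shared core.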